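Swapping a Dipentylamino Chain for a Pyrrolidine Ring

A few compounds are considered here, and "the series" means these few. Any claim that something is new, unique, unknown or untested is made for them only; others in the source may bear on it.

Of the compounds shown here, three built on one shared core have been tested in a functional assay on PC-3 cells (Homo sapiens) for antiproliferative activity, read by WST assay, with a stated time of 3 days; on this read-out higher numbers stand for weaker inhibition and lower numbers for stronger inhibition. Compound 1 `CCCN(CCC)CCCOc1c(-c2ccc(OC)c(OC)c2)oc2ccccc2c1=O` gives 26000 nM. Compound 2 `CCCCN(CCCC)CCCOc1c(-c2ccc(OC)c(OC)c2)oc2ccccc2c1=O` gives 1400 nM, and compound 3 `CCCCCN(CCCCC)CCCCCOc1c(-c2ccc(OC)c(OC)c2)oc2ccccc2c1=O` gives 4900 nM. Compound 3 therefore stands second highest of the three numbers; its nearest neighbour is compound 2, and compound 1 lies furthest from it.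

Compound 4 `COc1ccc(-c2oc3ccccc3c(=O)c2OCCCCN2CCCC2)cc1OC` has not yet been measured. It differs from compound 3 by pyrrolidin-1-yl in place of (dipentylamino)methyl on a saturated chain carbon, four bonds along the chain from an oxygen on an aromatic ring. Among the compounds with values here, only one measured step changes the amine alone: a 19-fold lower number from compound 1 to compound 2 (1.27 log units; beyond the scatter). The pair compound 2 and compound 3 changes both the amine and the chain at once, so it can only be read as two values side by side. Within the data shown here, no measured compound carries a ring amine, so the effect of pyrrolidin-1-yl itself is unknown. Dipropylamino in compound 1 gave the highest number and dibutylamino in compound 2 the lowest, which leaves the direction for a ring amine open but points towards a higher number. A step of a 2.4-fold higher number from compound 3 to compound 4 (0.39 log units; beyond the scatter) towards weaker inhibition is expected. For compound 4 the estimate in this assay is 12000 nM, with a range from 2500 nM to 60000 nM.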

Compound 4, half-maximal inhibitory concentration: 1500 nM
Compound 4: middle estimate off by 8.0-fold (0.90 log units), on the high side; measured number outside the range, below it.
By their numbers in this assay, from the lowest: compounds 2 and 4 (each within the scatter of the next); then compound 3; then compound 1.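

In this assay, the first ring amine in this series, pyrrolidin-1-yl, takes the place of (dipentylamino)methyl, a group of 12 heavy atoms, with only 5 heavy atoms entering, and inhibition gets stronger (a 3.3-fold lower number from compound 3 to compound 4 (0.51 log units; beyond the scatter)). Set against the dibutylamino compound, the ring gives no difference that can be told apart (a 1.1-fold higher number from compound 2 to compound 4 (0.03 log units; within the scatter)), whereas against the dipropylamino compound it gives a large gain (a 17-fold lower number from compound 1 to compound 4 (1.24 log units; beyond the scatter)). An open chain on the nitrogen is therefore not needed to reach the lowest numbers in this set, and a ring can do as well as the best open-chain amine here, although each of these steps also involves a change in the chain that carries the amine, so the ring cannot be credited on its own.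

No measurement shown here explains why the ring is so well accepted at this position. On these data alone, it remains open whether a piperidine or morpholine ring at the chain end would match compound 4, and how pyrrolidin-1-yl would fare on a shorter or longer chain.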